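The source may hold more compounds than are shown below. What is called first, only, known or untested is meant among the compounds shown, and "the series" means these compounds.

Measured so far, in an assay on microsomes from intestine for inhibition of acyl-CoA:cholesterol acyltransferase (Oryctolagus cuniculus); on this read-out higher numbers stand for weaker inhibition and lower numbers for stronger inhibition:
- compound 1, `CCCCCCCCN1NN=C(NC(=O)Nc2c(C(C)C)cccc2C(C)C)N1`, gives 59 nM
- compound 2, `CCCCCCCCCN1NN=C(NC(=O)Nc2c(C(C)C)cccc2C(C)C)N1`, gives 31 nM
- compound 3, `CCCCCCCCCCCN1NN=C(NC(=O)Nc2c(C(C)C)cccc2C(C)C)N1`, gives 9 nM

All three share the same core and differ only in the length of the saturated chain on the ring nitrogen. Compound 3 has the lowest number of the three: its step from compound 2 is a 3.4-fold lower number from compound 2 to compound 3 (0.54 log units; beyond the scatter), and from compound 1 it is a 6.6-fold lower number from compound 1 to compound 3 (0.82 log units; beyond the scatter), both beyond the scatter. The step of a 1.9-fold lower number from compound 1 to compound 2 (0.28 log units; within the scatter) between the two shorter chains is within the scatter.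

Compound 4, `COC(=O)CCCCCCCCCCN1NN=C(NC(=O)Nc2c(C(C)C)cccc2C(C)C)N1`, keeps the chain of compound 3 but alters its end: methoxycarbonyl in place of methyl on a saturated chain carbon, ten or more bonds along the chain from an amine nitrogen in a ring. Among the compounds with values here, no measured step changes a chain end in this way; the three steps only lengthen the chain by adding carbons, and each longer chain gave a lower or similar number. The change to compound 4 also lengthens the chain by heavy atoms, but with oxygen rather than carbon, so the measured steps bear on it only indirectly. A step in this assay of a 1.7-fold higher number from compound 3 to compound 4 (0.22 log units; within the scatter) is expected, within or close to the scatter. Compound 4 is therefore estimated at 15 nM, with a range from 5 nM to 45 nM.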

Compound 4, half-maximal inhibitory concentration: 4700 nM
Beside the measured number, compound 4's estimate is 310-fold (2.50 log units) below it, and the stated range ends below it.
By their numbers in this assay, from the lowest: compound 3; then compounds 2 and 1 (each within the scatter of the next); then compound 4.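

In this assay, the end of the chain matters far more than any change in length seen so far: methoxycarbonyl in place of methyl gives a 520-fold higher number from compound 3 to compound 4 (2.72 log units; beyond the scatter) and so undoes the gain from the longer chain and much more. Compound 4 also stands well apart from the shorter all-carbon chains, with a 150-fold higher number from compound 2 to compound 4 (2.18 log units; beyond the scatter) and an 80-fold higher number from compound 1 to compound 4 (1.90 log units; beyond the scatter) in the same direction, so the earlier pattern of longer chains giving lower or similar numbers does not extend to a chain ending in methoxycarbonyl. Nothing measured here explains why this end group costs so much.

Going by these compounds, it remains open whether this loss belongs to methoxycarbonyl in particular or would also follow from other oxygen- or nitrogen-bearing ends at the same place, such as a carboxylic acid, a primary amide, a hydroxyl or a methoxy group. On these data alone, it is also open whether a still longer all-carbon chain would keep lowering the number or whether the trend stops beyond the chain of compound 3.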